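The compounds below may be only part of what the source reports. "The series", "measured", "known", "first", "only" and "open" are said of these compounds alone.

Measured compounds:
Compound 1, `Oc1ccc(-c2cc(-c3ccccc3C(F)(F)F)cc(-c3ccc(O)cc3)n2)cc1`: in a functional assay on HeLa cells (Homo sapiens) for inhibition (a higher number here means a weaker inhibitor, a lower number a stronger inhibitor), compound 1 is given only as a limit, > 50000 nM.
Compound 2, `Oc1cccc(-c2cc(-c3ccccc3OC(F)(F)F)cc(-c3ccccc3O)n2)c1`: in this assay compound 2 gives 15200 nM.
Compound 3, `Oc1ccc(-c2cc(-c3ccccc3OC(F)(F)F)cc(-c3ccccc3O)n2)cc1`: in this assay compound 3 gives 6010 nM.

Compound 3 holds the lowest of the two numbers; compound 2 stands beyond the scatter above it, and compound 1 sits at the limit (the limit of > 50000 nM in this assay, at which 1 of the 3 values shown sits). Compound 4 is `Oc1ccc(-c2cc(-c3ccccc3OC(F)(F)F)cc(-c3ccc(O)cc3)n2)cc1`; against compound 3 the change is 4-hydroxyphenyl in place of 2-hydroxyphenyl on an aromatic carbon. For the measured compounds named here, the one measured step that bears on this is a 2.5-fold lower number from compound 2 to compound 3 (0.40 log units; beyond the scatter), a shift of the hydroxy group on the other aryl ring. Compound 1, which also carries two 4-hydroxyphenyl groups but trifluoromethyl rather than trifluoromethoxy, shows only a limit. A small gain is expected, a 1.5-fold lower number from compound 3 to compound 4 (0.18 log units; within the scatter). Compound 4 is estimated at 4000 nM in this assay, within 1500 nM to 15000 nM.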

Compound 4, half-maximal inhibitory concentration: 44600 nM
For compound 4 the middle estimate is 11-fold (1.05 log units) below the measured one; the measured number lies above the stated range.
By their numbers in this assay, from the lowest: compound 3; then compound 2; then compound 4. At a limit, above all of these: compound 1.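

In this assay, 4-hydroxyphenyl in place of 2-hydroxyphenyl on an aromatic carbon next to the ring nitrogen gives a 7.4-fold higher number from compound 3 to compound 4 (0.87 log units; beyond the scatter). This runs opposite to the step on the other aryl ring, a 2.5-fold lower number from compound 2 to compound 3 (0.40 log units; beyond the scatter), so a 4-hydroxyphenyl group does not carry the same outcome from one position to the other. Compound 1 is given only as a limit: the limit of > 50000 nM in this assay, at which 1 of the 4 values shown sits. Trifluoromethoxy in place of trifluoromethyl on an aromatic carbon gives an at least 1.1-fold lower number from compound 1 to compound 4 (0.04 log units; that floor lies within the scatter), so this step offers only a floor.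

Open, as far as these compounds go, is whether the hydroxy group itself matters at this position, or whether 2-methoxyphenyl or 2-aminophenyl would match compound 3.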